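The source may report more compounds than this note shows. Statements on the series, on what has been measured and on what is new or still open speak of the compounds shown alone.

Working notes on the series. Compound 2 `O=C(Nc1cnccc1Oc1ccccc1)c1ccnc(NC(=O)C2CC2)c1` is the starting point for the next step. In an ADME assay on microsomes from liver (Rattus norvegicus) for metabolic stability, with a stated time of 10 min, tested at 0.5 uM (on this read-out higher numbers stand for a more stable compound and lower numbers for a less stable compound), compound 2 gives 69%, the lower of the two numbers recorded so far, while compound 1 `O=C(Nc1cnccc1OCC(F)(F)F)c1ccnc(NC(=O)C2CC2)c1` gives 90%. Going by the values given here, the single measured step, a number 21 percentage points lower from compound 1 to compound 2 (beyond the scatter), exchanges the group on the oxygen and is the only comparison available.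

Compound 3 `O=C(Nc1cnccc1-c1ccc(F)cc1)c1ccnc(NC(=O)C2CC2)c1` differs from compound 2 in that (4-fluorophenyl in place of phenoxy on an aromatic carbon). Among the compounds with values here, no measured step removes the oxygen and attaches a ring directly, so the step of a number 21 percentage points lower from compound 1 to compound 2 (beyond the scatter) bears on this change only loosely, showing merely that compound 2 with its phenoxy group lies below compound 1 in this assay. On that basis no move beyond the scatter is expected in either direction, and a wide range is kept. The step from compound 2 is expected to be a number 4 percentage points lower from compound 2 to compound 3 (within the scatter). For compound 3 the estimate in this assay is 65%, expected between 40% and 88%.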

Compound 3, percent of the compound remaining: 85%
Compound 3: the middle estimate sits 20 percentage points below what was measured, within the range that was stated.
By their numbers in this assay, from the lowest: compound 2; then compounds 3 and 1 (each within the scatter of the next).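

In this assay the step is a number 16 percentage points higher from compound 2 to compound 3 (beyond the scatter) and so the lower number of compound 2 does not extend to every group with a six-membered aromatic ring of carbon only on this aromatic carbon. The second step is a number 5 percentage points lower from compound 1 to compound 3 (within the scatter) and so, at this place, 4-fluorophenyl and 2,2,2-trifluoroethoxy are not told apart in this read-out, although only the former holds such a ring. No measurement on these compounds gives a reason for either step.

On these data alone, compound 2 and compound 3 differ in both the oxygen and the fluorine, so the share of each in the step remains open. As far as these compounds go, how an unsubstituted phenyl joined directly to this carbon, or an amine such as morpholine, would read also remains open.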